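Microsomal half-life notes on a small aryl sulfonamide set

A few compounds are considered here, and "the series" means these few. Any claim that something is new, unique, unknown or untested is made for them only; others in the source may bear on it.

Measured so far:
compound 1 `Cc1ccc(CSc2cc(Cl)c(C)cc2S(=O)(=O)/N=C(\N)n2nc(C)cc2-c2ccccc2)cc1` gives 0.176 h
compound 2 `Cc1cc(-c2ccccc2)n(/C(N)=N/S(=O)(=O)c2cc(C)c(Cl)cc2SCc2ccc(C(F)(F)F)cc2)n1` gives 0.241 h
compound 3 `Cc1cccc(CSc2cc(Cl)c(C)cc2S(=O)(=O)/N=C(\N)n2nc(C)cc2-c2ccccc2)c1` gives 0.214 h

In an ADME assay on microsomes from liver (Homo sapiens) for metabolic stability, read by LC-MS, using NADPH, tested at 5 uM (on this read-out lower numbers stand for a shorter-lived compound and higher numbers for a longer-lived compound), compound 1 stands at the low end of the three numbers, but its neighbours sit close: a 1.2-fold higher number from compound 1 to compound 3 (0.08 log units; within the scatter) and a 1.4-fold higher number from compound 1 to compound 2 (0.14 log units; within the scatter), so no order among them can be read. The third comparison, a 1.1-fold lower number from compound 2 to compound 3 (0.05 log units; within the scatter), likewise shows nothing.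

Compound 4 `Cc1ccc(CSc2cc(Cl)c(C)cc2S(=O)(=O)/N=C(\N)n2nccc2-c2ccccc2)cc1` departs from compound 1 by hydrogen in place of methyl on an aromatic carbon. Among the measured compounds shown here, none of the measured steps touches this five-membered ring; all three change only the group on the saturated chain carbon bound to a sulfur, and all three lie within scatter. No direct guide exists for this change, so a step no larger than the scatter is expected: a 1.0-fold higher number from compound 1 to compound 4 (0.01 log units; within the scatter). Compound 4 is estimated at 0.18 h, with a range from 0.09 h to 0.36 h.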

Compound 4, half-life: 0.13 h
Compound 4: middle estimate off by 1.4-fold (0.14 log units), on the high side; measured number inside the range.
By their numbers in this assay, from the lowest: compounds 4, 1, 3 and 2 (each within the scatter of the next).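

The only step at this ring position, hydrogen in place of methyl, gives in this assay a 1.4-fold lower number from compound 1 to compound 4 (0.13 log units; within the scatter), so the methyl on this aromatic carbon, like the group on the saturated chain carbon, has shown no readable step. Nothing at hand bears on what lies behind this result.

Open, as far as these compounds go, is whether an ethyl chain, an amine or a carboxylic acid on this aromatic carbon would move the half-life beyond the scatter. Also open, from the compounds shown here alone, is whether the same exchange behaves alike with the 4-(trifluoromethyl)phenyl group of compound 2 on the chain carbon.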